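The source may report more compounds than this note shows. Statements on the series, on what has been measured and on what is new or still open speak of the compounds shown alone.

Compound 2 `COc1cc(OCc2csc(-c3cccc(C(=O)N(C)C)c3)n2)c2cc(-c3cn4nc(OC)sc4n3)oc2c1` is one of a small set of antagonists built on a shared core, tested in a functional assay on HEK293 cells for antagonist activity at proteinase-activated receptor 4 (Homo sapiens), read by FLIPR and calcium flux, with a stated time of 30 min; on this read-out lower numbers stand for stronger inhibition and higher numbers for weaker inhibition. On that read-out compound 2 gives 0.8 nM. Its nearest neighbour is compound 1 `COc1cc(OCc2csc(-c3ccc(OC)nc3)n2)c2cc(-c3cn4nc(OC)sc4n3)oc2c1`, which in this assay gives 0.8 nM, so the two stand level at the digits shown, and the step of no change at the digits printed from compound 1 to compound 2 (within the scatter) lies within the usual scatter. Compound 3 `COc1cc(OCc2cccc(-c3ccc(C#N)cc3)c2)c2cc(-c3cn4nc(OC)sc4n3)oc2c1` belongs to the same set, but in this assay compound 3 has only "nd" (no result reported), so no result is reported for it.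

The next compound, compound 4 `COc1cc(OCc2csc(-c3ccc(C(=O)O)cc3)n2)c2cc(-c3cn4nc(OC)sc4n3)oc2c1`, differs from compound 2 in a single place: 4-carboxyphenyl in place of 3-(dimethylcarbamoyl)phenyl on an aromatic carbon. Among the measured compounds shown here, the only measured step that bears on this position is no change at the digits printed from compound 1 to compound 2 (within the scatter), which shows that exchanging one aromatic group for another at this place left the number unchanged within the scatter. That single step is the whole of the evidence; nothing measured tells how a carboxylic acid at this position behaves.

On that basis compound 4 is expected to stay close to compound 2, with a step of a 2.5-fold higher number from compound 2 to compound 4 (0.40 log units; beyond the scatter) that is estimated to sit within or near the scatter. For compound 4 the expected value in this assay is 2 nM, with a range from 0.5 nM to 10 nM.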

Compound 4, half-maximal inhibitory concentration: 1.1 nM
For compound 4 the middle estimate is 1.8-fold (0.26 log units) above the measured one; measured number inside the range.
By their numbers in this assay, from the lowest: compounds 1, 2 and 4 (each within the scatter of the next).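

In this assay, the step of a 1.4-fold higher number from compound 2 to compound 4 (0.14 log units; within the scatter) shows that this place on the five-membered aromatic ring also accepts 4-carboxyphenyl, a group with a hydrogen-bond donor where 3-(dimethylcarbamoyl)phenyl has none, and the difference stays within the scatter. The step of a 1.4-fold higher number from compound 1 to compound 4 (0.14 log units; within the scatter) reads the same way, so the three groups seen at this place in compounds 1, 2 and 4, namely 6-methoxypyridin-3-yl, 3-(dimethylcarbamoyl)phenyl and 4-carboxyphenyl, cannot be told apart on this read-out. Nothing in the data shown accounts for this tolerance.

All three of these groups carry a six-membered aromatic ring, so the compounds shown leave open what happens at this place when that ring gives way to a saturated amine such as piperidine or to a plain longer carbon chain. Among the compounds shown here, compound 3 has no reported result, so no step to it can be read, and it adds nothing on this question.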